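Heptyl addition to compound 1: expected solubility step

This account rests on a few compounds, and the source may have more. Where it says the series, first, only, none or still open, it means among the compounds named here.

For the measured compounds named here, in a physicochemical assay for solubility, read by HPLC, at pH 7.4 (on this read-out higher numbers stand for higher solubility and lower numbers for lower solubility), compound 1 (`CCc1c(C)[nH]c2cc(OC)c(Cl)cc2c1=O`) gives 10000 nM, the higher of the two numbers so far. The bromo counterpart, compound 2 (`CCc1c(C)[nH]c2cc(OC)c(Br)cc2c1=O`), gives 2000 nM. Compound 3 (`CCCCCCCCCc1c(C)[nH]c2cc(OC)c(Cl)cc2c1=O`) has not been measured. Its change from compound 1 is heptyl in place of hydrogen on a saturated chain carbon, two bonds along the chain from an aromatic carbon. Cut one bond further out, the same difference reads methyl to octyl.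

Going by the values given here, only one measured step is available, and it bears on this change only indirectly: a 5.0-fold lower number from compound 1 to compound 2 (0.70 log units; beyond the scatter), a modest step beyond the scatter for bromo in place of chloro on an aromatic carbon. Among the compounds with values here, no measured compound varies the chain, so the size of the new step is poorly constrained. With the halogen swap alone giving a 5.0-fold lower number from compound 1 to compound 2 (0.70 log units; beyond the scatter), a larger step in this assay towards lower numbers is expected from the much larger heptyl addition. The estimate is a 33-fold lower number from compound 1 to compound 3 (1.52 log units; beyond the scatter), an expected drop well beyond the scatter. For compound 3 the estimated value is 300 nM, with an expected range of 50 nM to 2000 nM.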

Compound 3, solubility: < 2000 nM
Compound 3: no number, only a limit (the forecaster's own chance of this, stated with the estimate: 25%); the middle value lies beyond the limit too.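

In this assay compound 3 reads < 2000 nM, which is a limit of the assay and not a number. This gives the first read on the chain carbon, where heptyl in place of hydrogen on a saturated chain carbon, two bonds along the chain from an aromatic carbon, produces an at least 5.0-fold lower number from compound 1 to compound 3 (0.69 log units; beyond the scatter). The earlier compounds varied only the halogen, with a 5.0-fold lower number from compound 1 to compound 2 (0.70 log units; beyond the scatter), and the new step shows that the chain position also moves this read-out, although the limit fixes only the smallest size of the step: the limit of < 2000 nM in this assay, at which 1 of the 3 values shown sits.

The compounds shown leave open how far compound 3 lies past its limit, and therefore whether the chain change outweighs the halogen change or merely matches it. They also leave open how the read-out follows chain length and chain end, which a propyl or pentyl chain, or a chain of similar length ending in an amine or a carboxylic acid, would address, as would the heptyl change on the bromo compound 2.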